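Tetrabromobenzotriazoles: from a hydroxybutyl chain to a dihydroxypropyl one

This account rests on a few compounds, and the source may have more. Where it says the series, first, only, none or still open, it means among the compounds named here.

Of the compounds shown here, three sharing a tetrabrominated core have been tested in a functional assay on CCRF-CEM cells (Homo sapiens) for antiproliferative activity, read by MTT assay, with a stated time of 24 h, tested at 12.5 uM; on this read-out lower numbers stand for a stronger effect and higher numbers for a weaker effect at the one concentration tested. Compound 1 `C[C@@H](O)CCn1nc2c(Br)c(Br)c(Br)c(Br)c2n1` gives 88% in this assay. Compound 2 `OC(CCn1nc2c(Br)c(Br)c(Br)c(Br)c2n1)c1ccccc1` gives 122% in this assay. Compound 3 `C[C@H](O)CCn1nc2c(Br)c(Br)c(Br)c(Br)c2n1` gives 126% in this assay, the highest of the three numbers, with compound 2 within the scatter of it and compound 1 well apart. Among the compounds with values here, the only step between two compounds differing in one place is a number 38 percentage points higher from compound 1 to compound 3 (beyond the scatter), which is a large shift that rests solely on (the fact that compounds 1 and 3 differ only in the configuration as drawn).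

Compound 4 `OCC(O)Cn1nc2c(Br)c(Br)c(Br)c(Br)c2n1` has not yet been measured. It differs from compound 3 by 1,2-dihydroxyethyl in place of 2-hydroxypropyl on a saturated chain carbon bound to an aromatic nitrogen. Within the data shown here, no measured step changes the side chain in this way, so the stereochemical step between compound 1 and compound 3 offers only a loose guide to how widely numbers can move. Compound 4 is therefore expected to land somewhere between the two bands seen so far, with a number 14 percentage points lower from compound 3 to compound 4 (beyond the scatter) as the estimated step. The estimate for compound 4 in this assay is 112%, with a range from 85% to 135%.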

Compound 4, a percentage reported as activity, at one concentration (the size of the read-out at that concentration, not a potency): 78%
For compound 4 the middle estimate is 34 percentage points above the measured one; measured number below the stated range.
By their numbers in this assay, from the lowest: compounds 4 and 1 (each within the scatter of the next); then compounds 2 and 3 (each within the scatter of the next).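

In this assay, the change from 3-hydroxybutyl to 2,3-dihydroxypropyl on a saturated chain carbon bound to an aromatic nitrogen gives a number 48 percentage points lower from compound 3 to compound 4 (beyond the scatter), yet it gives a number 10 percentage points lower from compound 1 to compound 4 (within the scatter). The same change in group therefore reads as large or as nothing beyond the scatter, depending on which drawn form of the chain it starts from. The two starting points differ in one respect only: the fact that compounds 1 and 3 differ only in the configuration as drawn.

The compounds shown leave open whether the two configurations of the 2,3-dihydroxypropyl chain would separate as widely as those of the 3-hydroxybutyl chain do. They also leave open how an amine or a carboxylic acid on this chain, or a longer chain bearing the same two hydroxyl groups, would read in this assay.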